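Lipophilicity of a Hydrazone Series: A Predicted Step

The source may hold more compounds than are shown below. What is called first, only, known or untested is meant among the compounds shown, and "the series" means these compounds.

Of the compounds shown here, three of one family have been measured in a physicochemical assay for lipophilicity, in phosphate buffer, measured as octanol-water partition, with a stated time of 24 h; a higher number here means a more lipophilic compound, a lower number a more polar compound. Compound 1 `Fc1ccc(Oc2ccc(/C=N/Nc3nc4ccccc4s3)cc2)cc1` gives 5. Compound 3 `Cc1cc(Oc2ccc(/C=N/Nc3nc4ccccc4s3)cc2)ccc1Cl` gives 5.5, and compound 2 `O=C(CSc1nc2ccccc2s1)N/N=C/c1ccc(Oc2ccc(F)cc2)cc1` gives 5.5. Compound 2 therefore sits level with compound 3 at the digits shown, the two of them together forming the highest pair of the three numbers, while compound 1 lies lower by an amount beyond the scatter.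

One single-point comparison exists among the measured compounds: the change a number 0.50 log units higher from compound 1 to compound 3 (beyond the scatter), where the change is 4-chloro-3-methylphenyl in place of 4-fluorophenyl on an oxygen on an aromatic ring.

Compound 4 `Cc1cc(Oc2ccc(/C=N/NC(=O)CSc3nc4ccccc4s3)cc2)ccc1Cl` has not yet been measured. It differs from compound 2 by 4-chloro-3-methylphenyl in place of 4-fluorophenyl on an oxygen on an aromatic ring. Among the compounds with values here, this is the same change as the one separating compound 1 from compound 3, only set on the core of compound 2 rather than that of compound 1. The expected step is a number 0.50 log units higher from compound 2 to compound 4 (beyond the scatter), because the matching change gave a number 0.50 log units higher from compound 1 to compound 3 (beyond the scatter), a modest rise beyond the scatter. On that basis, compound 4 is expected to reach about 6 in this assay, with a range from 5.6 to 6.4.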

Compound 4, partition coefficient: 5.7
Compound 4: the middle estimate sits 0.30 log units above what was measured, within the range that was stated.
By their numbers in this assay, from the lowest: compound 1; then compounds 2, 3 and 4 (each within the scatter of the next).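

Within the data shown here, until now, 4-chloro-3-methylphenyl in place of 4-fluorophenyl had been seen on only one core, where this assay gave a number 0.50 log units higher from compound 1 to compound 3 (beyond the scatter) and the step stood clear of the usual scatter. On the second core, the same change at the same place gives a number 0.20 log units higher from compound 2 to compound 4 (within the scatter) and so cannot be told apart from repeat-measurement noise. The step seen on the first core therefore does not carry over as a clear rise in this pair, which shows that the core can matter to how this change reads, and nothing at hand explains why the two pairs differ.

Among these compounds, with only two pairs, it remains open how this change would read on a third core, or whether a repeat of these measurements would bring the two steps closer together or move them further apart. Among the compounds shown here, only two groups appear at this place on an oxygen on an aromatic ring, so a phenyl ring carrying an amine or a carboxylic acid could still give quite different numbers on either core.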